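This account rests on a few compounds, and the source may have more. Where it says the series, first, only, none or still open, it means among the compounds named here.

Compound 1 `COc1cccc(OC)c1OCCNCCOc1ccccc1OCc1ccccc1` gives 76900 nM in a functional assay on PC-3 cells (Homo sapiens) for cytotoxicity, read by sulforhodamine B assay; a higher number here means a weaker inhibitor of growth, a lower number a stronger inhibitor of growth.
Compound 2 `COc1cccc(OC)c1OCCNCCOc1ccccc1OCc1ccccc1C` gives 33900 nM.
Compound 3 `COc1cccc(OC)c1OCCNCCOc1ccccc1OCc1cccc(C)c1` gives 32300 nM.

Among these three numbers compound 3 has the lowest, yet compound 2 stands so close that the gap, a 1.0-fold lower number from compound 2 to compound 3 (0.02 log units; within the scatter), falls within the scatter; only compound 1 is clearly set apart, its number higher by a 2.4-fold lower number from compound 1 to compound 3 (0.38 log units; beyond the scatter). The two steps that add a methyl to the benzyl ring, a 2.3-fold lower number from compound 1 to compound 2 (0.36 log units; beyond the scatter) and a 2.4-fold lower number from compound 1 to compound 3 (0.38 log units; beyond the scatter), are both modest and point the same way, while moving the methyl from one aromatic carbon to another changes nothing detectable.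

Compound 4 `COc1ccccc1COc1ccccc1OCCNCCOc1c(OC)cccc1OC` is the next step from compound 3: 2-methoxyphenyl in place of 3-methylphenyl on a saturated chain carbon bound to an oxygen on an aromatic ring. Going by the values given here, the measured steps bear on it only indirectly, since no compound yet carries a methoxy on this ring. They show that a small group on the benzyl ring lowers the number modestly and that its position mattered little, so compound 4 is expected to land near compound 2 and compound 3, with a 1.1-fold higher number from compound 3 to compound 4 (0.05 log units; within the scatter) expected to stay within the scatter. The estimate for compound 4 in this assay is 36000 nM, within a range from 15000 nM to 85000 nM.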

Compound 4, concentration for total growth inhibition: 30200 nM
Estimate against measurement, compound 4: 1.2-fold (0.08 log units) above, within the range that was stated.
By their numbers in this assay, from the lowest: compounds 4, 3 and 2 (each within the scatter of the next); then compound 1.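

In this assay, 2-methoxyphenyl in place of 3-methylphenyl on a saturated chain carbon bound to an oxygen on an aromatic ring brings in an oxygen and a hydrogen-bond acceptor, yet the result is a 1.1-fold lower number from compound 3 to compound 4 (0.03 log units; within the scatter). Methoxy in place of methyl on an aromatic carbon reads the same way, with a 1.1-fold lower number from compound 2 to compound 4 (0.05 log units; within the scatter), while methoxy in place of hydrogen gives a 2.5-fold lower number from compound 1 to compound 4 (0.41 log units; beyond the scatter), so a methoxy group at this place yields a modest step of the same kind as the two methyl groups, and none of the three substituted compounds goes against this. No evidence at hand explains why these different groups read alike here.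

The compounds shown leave open whether a chlorine, a hydroxyl, an amine or a carboxylic acid at this place would stay within the same narrow band or move the number further. They also leave open whether 3-methoxyphenyl would read like 2-methoxyphenyl, as 3-methylphenyl reads like 2-methylphenyl, and whether a longer chain in place of methoxy would change the picture.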